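Halogen swaps on a chlorophenyl-oxadiazole pyrrolidine urea

The compounds below may be only part of what the source reports. "The series", "measured", "known", "first", "only" and "open" are said of these compounds alone.

Compound 1, `O=C(Nc1ccc(Cl)cc1)N1CCC[C@H]1c1nc(-c2cccc(Cl)c2)no1`: in an ADME assay on MCF-10A cells (Homo sapiens) for inhibition, with a stated time of 48 h (on this read-out higher numbers stand for weaker inhibition and lower numbers for stronger inhibition), compound 1 gives > 50000 nM, a limit of the assay rather than a number.
Compound 2, `O=C(Nc1ccc(Cl)cc1)N1CCC[C@H]1c1nc(-c2cccc(Br)c2)no1`: compound 2 gives > 50000 nM, again a limit of the assay.
Compound 3, `O=C(Nc1ccc(Cl)cc1)N1CCC[C@H]1c1nc(-c2ccc(Cl)cc2)no1`: compound 3 gives > 50000 nM, also a limit of the assay.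

The change from compound 1 to compound 2 is bromo in place of chloro on an aromatic carbon, and on this read-out it made a step that the two limits leave unreadable from compound 1 to compound 2. Compound 1 and compound 3 differ in their cores by 4-chlorophenyl in place of 3-chlorophenyl on an aromatic carbon; this gave a step that the two limits leave unreadable from compound 1 to compound 3, and from compound 2 the same kind of comparison gave a step that the two limits leave unreadable from compound 2 to compound 3. Compound 4, `O=C(Nc1ccc(Cl)cc1)N1CCC[C@H]1c1nc(-c2ccc(Br)cc2)no1`, has not yet been measured and differs from compound 3 by bromo in place of chloro on an aromatic carbon. For the measured compounds named here, that is the same kind of change as the one from compound 1 to compound 2, but the place is not the same: in compound 2 the bromo sits meta to a large group, in compound 4 it sits para to a large group. In this assay the step is expected to be a step that the limit leaves unreadable from compound 3 to compound 4; this expectation rests on (the limit of > 50000 nM in this assay, at which 3 of the 3 values shown sit). Compound 4 is therefore estimated at 80000 nM, most likely reported once more only as a limit.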

Compound 4, half-maximal inhibitory concentration: > 50000 nM
Compound 4 ended at the assay's limit; the forecaster's own chance of this, stated with the estimate: 85%; the middle value does not contradict the limit.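

In this assay compound 4 stays at the limit, as do compound 1, compound 2 and compound 3, so no step among these four compounds can be read. The compounds shown leave open whether either halogen, in either place on the phenyl ring, changes the inhibition measured in this assay at all.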